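Aryl amides of the succinate acid in this series

The compounds below may be only part of what the source reports. "The series", "measured", "known", "first", "only" and "open" are said of these compounds alone.

Compound 1 `O=C(O)CCC(=O)OCCCCCCSc1ccc([N+](=O)[O-])c2nonc12` gives the lowest number of the three measured compounds: in an assay on isolated protein for inhibition of glutathione S-transferase Mu 2 (Homo sapiens), with a stated time of 10 min (a higher number here means a weaker inhibitor, a lower number a stronger inhibitor), compound 1 gives 160 nM. Compound 2 `Cc1ccccc1NC(=O)CCC(=O)OCCCCCCSc1ccc([N+](=O)[O-])c2nonc12` gives 440 nM in this assay, and compound 3 `O=C(CCC(=O)OCCCCCCSc1ccc([N+](=O)[O-])c2nonc12)Nc1ccc(Br)cc1` gives 32000 nM.

Compound 4 `O=C(CCC(=O)OCCCCCCSc1ccc([N+](=O)[O-])c2nonc12)Nc1ccc(C(F)(F)F)cc1` differs from compound 1 by (4-(trifluoromethyl)phenyl)amino in place of hydroxy on a carbonyl carbon.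

For the measured compounds named here, two measured steps bear on this change, both replacing the same hydroxy with an arylamino group on the carbonyl carbon: a 2.8-fold higher number from compound 1 to compound 2 (0.44 log units; beyond the scatter) and a 200-fold higher number from compound 1 to compound 3 (2.30 log units; beyond the scatter). The gap between the two amides is itself large, a 73-fold higher number from compound 2 to compound 3 (1.86 log units; beyond the scatter). Compound 4 is closer in kind to compound 3 than to compound 2, in that its nitrogen carries a 4-(trifluoromethyl)phenyl where compound 3 carries a 4-bromophenyl, each a phenyl bearing a single substituent named at its 4-position, rather than the 2-methylphenyl of compound 2. Going by the values given here, with only two amide examples, the weight of compound 3 suggests a large step up, though compound 2 shows that not every amide loses much.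

A large increase is therefore expected, a 94-fold higher number from compound 1 to compound 4 (1.97 log units; beyond the scatter). For compound 4 the estimate in this assay is 15000 nM, with a range from 2500 nM to 60000 nM.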

Compound 4, half-maximal inhibitory concentration: 90 nM
Compound 4: the middle estimate sits 170-fold (2.22 log units) above what was measured, outside the stated range (below it).
By their numbers in this assay, from the lowest: compounds 4 and 1 (each within the scatter of the next); then compound 2; then compound 3.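

In this assay, an arylamino group in place of hydroxy on a carbonyl carbon need not shift the number beyond the scatter: a 1.8-fold lower number from compound 1 to compound 4 (0.25 log units; within the scatter). The large loss seen with compound 3 therefore does not extend to every amide of this type, and a single substituent change on the aromatic ring separates the two outcomes, with trifluoromethyl in place of bromo on an aromatic carbon giving a 360-fold lower number from compound 3 to compound 4 (2.55 log units; beyond the scatter). The aryl group also separates compound 4 from the other tolerated amide, a 4.9-fold lower number from compound 2 to compound 4 (0.69 log units; beyond the scatter), so compound 2 no longer marks the low end among the amides and the three aryl amides span a wide range in this assay.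

The compounds shown leave open whether 4-chlorophenyl, 4-methoxyphenyl or unsubstituted phenyl on the amide nitrogen would stay close to compound 4 or fall towards compound 3, and whether a saturated ring such as cyclohexyl would be accepted there. No measurement shown here accounts for the differences among these amides.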